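Hydroxymethyl in place of 4-methylphenyl: cytotoxicity outlook

This account rests on a few compounds, and the source may have more. Where it says the series, first, only, none or still open, it means among the compounds named here.

In an ADME assay on HEL cells (Homo sapiens) for cytotoxicity, read by cell counting, with a stated time of 3 days (a higher number here means that more compound is tolerated, a lower number that less compound is tolerated), compound 1 `CCCCCc1ccc(-c2oc3nc(=O)n([C@H]4C[C@H](OC(C)=O)[C@@H](COC(C)=O)O4)cc3c2C#Cc2ccc(C)cc2)cc1` gives 100000 nM. Compound 2 `CC(=O)OC[C@H]1O[C@@H](n2cc3c(C#CCCN4C(=O)c5ccccc5C4=O)c(-c4ccc(C)cc4)oc3nc2=O)C[C@@H]1OC(C)=O` gives 100000 nM in this assay, level with compound 1 within the scatter. Compound 3 `COCC#Cc1c(-c2ccc(C)cc2)oc2nc(=O)n([C@H]3C[C@H](OC(C)=O)[C@@H](COC(C)=O)O3)cc12` gives only a limit of the assay, > 100000 nM. Going by the values given here, the single step with two measured ends, a number no lower from compound 2 to compound 3 (the limit leaves the size open), swaps a large group for a small one on a saturated chain carbon bound to a triple-bonded carbon and did not lower the value. The limit is described by the limit of > 100000 nM in this assay, at which 1 of the 3 values shown sits. Compound 4 `CCCCCc1ccc(-c2oc3nc(=O)n([C@H]4C[C@H](OC(C)=O)[C@@H](COC(C)=O)O4)cc3c2C#CCO)cc1` differs from compound 1 thus: hydroxymethyl in place of 4-methylphenyl on a triple-bonded carbon. Since the measured values all sit at the top of the range, no change beyond the scatter is expected, and compound 4 is estimated at 100000 nM (50000 nM to 100000 nM). The expected step is therefore no change at the digits printed from compound 1 to compound 4 (within the scatter).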

Compound 4, minimum cytotoxic concentration: 100000 nM
For compound 4 middle estimate and measured number coincide at the digits printed, and the stated range covers the measured number.
By their numbers in this assay, from the lowest: compounds 1, 2 and 4 (each within the scatter of the next).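

In this assay, the step on the triple-bonded carbon can be read in size, unlike the earlier step on a saturated chain carbon: no change at the digits printed from compound 1 to compound 4 (within the scatter). Hydroxymethyl thus replaces 4-methylphenyl, losing the aromatic ring, without a change beyond the scatter. The reading still lies at the top of the range reported, so it shows only that this swap is tolerated there: the limit of > 100000 nM in this assay, at which 1 of the 4 values shown sits.

From the compounds shown here alone, whether an amine or a carboxylic acid on this triple-bonded carbon would also leave the number in place remains open. So does the effect of a longer chain ending in hydroxyl.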